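The source may report more compounds than this note shows. Statements on the series, on what has been measured and on what is new or still open speak of the compounds shown alone.

Compound 1 `Cc1ccc(C2=NN(C(=O)CN3CCCCC3)C(c3ccccc3O)C2)cc1`: 11300 nM
Compound 2 `O=C(CN1CCCCC1)N1N=C(c2ccccc2)CC1c1ccccc1O`: 9510 nM
Compound 3 `O=C(CN1CCCCC1)N1N=C(c2ccc(Cl)cc2)CC1c1ccccc1O`: 7250 nM

All three compounds share one core and differ only in the group on the pendant phenyl ring. In an assay on isolated protein for inhibition of Amine oxidase [flavin-containing] A (Homo sapiens), read by fluorescence, with stated times of 15 min and 20 min (on this read-out lower numbers stand for stronger inhibition and higher numbers for weaker inhibition), compound 3 sits at the low end of the three numbers shown, yet a 1.6-fold lower number from compound 1 to compound 3 (0.19 log units; within the scatter) and a 1.3-fold lower number from compound 2 to compound 3 (0.12 log units; within the scatter) both fall within the scatter, so the three compounds cannot be told apart on these numbers.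

Compound 4 `O=C(CN1CCCCC1)N1N=C(c2ccc(Cl)cc2)CC1c1cc(Cl)ccc1O` keeps everything in compound 3 and changes one place: chloro in place of hydrogen on an aromatic carbon. Within the data shown here, the only measured step of the same kind is a 1.3-fold lower number from compound 2 to compound 3 (0.12 log units; within the scatter), which also put chloro in place of hydrogen on an aromatic carbon, though on the other ring, and stayed within the scatter. Among the measured compounds shown here, no measured step touches the ring that carries the hydroxy group, so nothing in these data argues for a shift. The step from compound 3 to compound 4 is therefore expected to be a 1.1-fold lower number from compound 3 to compound 4 (0.05 log units; within the scatter), within the scatter. Compound 4 is estimated at 6500 nM, with a range from 2500 nM to 17000 nM.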

Compound 4, half-maximal inhibitory concentration: 6010 nM
Beside the measured number, compound 4's estimate is 1.1-fold (0.03 log units) above it; the range from low to high includes it.
By their numbers in this assay, from the lowest: compounds 4, 3, 2 and 1 (each within the scatter of the next).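

Among these compounds, this is the first measured step on the ring that carries the hydroxy group: in this assay, chloro on the aromatic carbon para to the hydroxy group gives a 1.2-fold lower number from compound 3 to compound 4 (0.08 log units; within the scatter) and so stays within the scatter. This position therefore takes a chlorine atom without a shift that can be told apart from repeat measurement, and the same swap on the other ring, a 1.3-fold lower number from compound 2 to compound 3 (0.12 log units; within the scatter), is also within the scatter. No measured evidence bears on this result.

From the compounds shown here alone, whether any other group at this position would move the number stays open, for example an amine or a carboxylic acid in place of the chloro. All four compounds also keep the hydroxy group, so what a methoxy group in its place would do is open too.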